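Shortening the sulfur-linked chain to a carbamoyl group

A few compounds are considered here, and "the series" means these few. Any claim that something is new, unique, unknown or untested is made for them only; others in the source may bear on it.

The shared core of compound 1 `O=c1nc(SCc2ccccc2)ccn1[C@@H]1O[C@H](COP(=O)(O)OP(=O)(O)O)[C@@H](O)[C@H]1O` carries a benzyl group on the sulfur; in an in vitro functional assay on 1321-N1 cells for agonist activity at P2Y purinoceptor 6 (Homo sapiens) (a lower number here means that less compound is needed, a higher number that more compound is needed for the effect), compound 1 gives 800 nM. Among the compounds with values here, compound 2 `O=C(O)CCCSc1ccn([C@@H]2O[C@H](COP(=O)(O)OP(=O)(O)O)[C@@H](O)[C@H]2O)c(=O)n1` replaces that group with a chain ending in a carboxylic acid and in this assay compound 2 gives 8800 nM, the highest of the two numbers known so far; the change from compound 1 to compound 2 produced an 11-fold higher number from compound 1 to compound 2 (1.04 log units; beyond the scatter). Compound 3 `NC(=O)CSc1ccn([C@@H]2O[C@H](COP(=O)(O)OP(=O)(O)O)[C@@H](O)[C@H]2O)c(=O)n1` differs from compound 2 by carbamoyl in place of 2-carboxyethyl on a saturated chain carbon bound to a sulfur. Within the data shown here, the only measured step, that from compound 1 to compound 2, shows that what sits on this chain carbon matters greatly, but no measured pair exchanges an acid for an amide or shortens the chain, so there is no direct precedent. Compound 3 is therefore expected to stay near compound 2, at 6000 nM with a wide range from 1500 nM to 25000 nM, a step of a 1.5-fold lower number from compound 2 to compound 3 (0.17 log units; within the scatter).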

Compound 3, half-maximal effective concentration: 18000 nM
Beside the measured number, compound 3's estimate is 3.0-fold (0.48 log units) below it; low and high end bracket the measured number.
By their numbers in this assay, from the lowest: compound 1; then compound 2; then compound 3.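

In this assay, carbamoyl in place of 2-carboxyethyl on a saturated chain carbon bound to a sulfur gives a 2.0-fold higher number from compound 2 to compound 3 (0.31 log units; beyond the scatter) and so moves the number further from that of compound 1, not back towards it. Set against the benzyl group of the shared core, the carbamoyl change gives a 23-fold higher number from compound 1 to compound 3 (1.35 log units; beyond the scatter) and leaves compound 3 with the highest number of the three, so neither replacement of phenyl shown here comes close to compound 1. Nothing available explains these differences.

In compound 3, 3-carboxypropyl gives way to carbamoylmethyl. Chain length and end group change together, and the compounds shown cannot separate the two. Open too, from the compounds shown here alone, is how a carboxylic acid on the shorter chain, an amide on the longer chain or an amine at the chain end would compare.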